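A few compounds are considered here, and "the series" means these few. Any claim that something is new, unique, unknown or untested is made for them only; others in the source may bear on it.

The measured compounds in a functional assay on U-87MG ATCC cells for antiproliferative activity against U-87 MG (Homo sapiens), read by MTT assay, with a stated time of 72 h; on this read-out lower numbers stand for stronger inhibition and higher numbers for weaker inhibition:

compound 1 `O=C(Nc1ccc(Oc2ccnc3[nH]ccc23)c(F)c1)c1cc2cccnc2n(-c2ccccc2)c1=O`, 1260 nM
compound 2 `O=C(Nc1ccc(Oc2ccnc3[nH]ccc23)c(F)c1)c1cc2cccnc2n(-c2ccc(F)cc2)c1=O`, 620 nM
compound 3 `O=C(Nc1ccc(Oc2ccnc3[nH]ccc23)c(F)c1)c1cc2cccnc2n(-c2ccc(F)c(Cl)c2)c1=O`, 5230 nM

Compound 2 gives the lowest number of the three in this assay. Compound 1 is the nearest to it, separated by a 2.0-fold lower number from compound 1 to compound 2 (0.31 log units; beyond the scatter), and compound 3 the furthest, separated by an 8.4-fold higher number from compound 2 to compound 3 (0.93 log units; beyond the scatter). Compound 3 also stands apart from compound 1 by a 4.2-fold higher number from compound 1 to compound 3 (0.62 log units; beyond the scatter). All three of these steps alter the ring that sits on the aromatic nitrogen of the shared core, and all three are of modest size.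

Compound 4 `Cn1ccc2c(Oc3ccc(NC(=O)c4cc5cccnc5n(-c5ccc(F)cc5)c4=O)cc3F)ccnc21` differs from compound 2 at a different place: methyl in place of hydrogen on an aromatic nitrogen, on an aromatic nitrogen of a five-membered aromatic ring with 1 nitrogen, part of a fused or bridged system of two rings. Going by the values given here, none of the measured steps touches this ring, so no measured step bears directly on the change; the three known steps concern another part of the molecule. With nothing in the data pointing either way, a step within the usual scatter is expected in this assay, with the range widened to allow for a modest shift in either direction. Compound 4 is therefore estimated at 1100 nM in this assay, between 350 nM and 3500 nM, which would mean a 1.8-fold higher number from compound 2 to compound 4 (0.25 log units; within the scatter).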

Compound 4, half-maximal inhibitory concentration: 1320 nM
For compound 4 the middle estimate is 1.2-fold (0.08 log units) below the measured one, within the range that was stated.
By their numbers in this assay, from the lowest: compound 2; then compounds 1 and 4 (each within the scatter of the next); then compound 3.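

In this assay, the change to this position gives a 2.1-fold higher number from compound 2 to compound 4 (0.33 log units; beyond the scatter), a modest step that lies beyond the scatter. Going by these compounds alone, it is the first evidence that the five-membered aromatic ring of the shared core, untouched by the earlier steps, also affects the read-out: methyl in place of hydrogen on its aromatic nitrogen moves the number away from the lowest value. The compounds shown offer no independent measurement that explains this rise, so the result records the size and direction of the step but not its origin.

The compounds shown leave open whether the rise follows from the loss of the hydrogen on this nitrogen or from the methyl that enters, a question that a longer chain such as ethyl or a 2-hydroxyethyl group at the same place could help to address. They also leave open whether the methyl step would keep its direction and size with phenyl or 3-chloro-4-fluorophenyl in place of the 4-fluorophenyl ring on the other aromatic nitrogen.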